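Aryl amide swap on the dinitro core

The compounds below may be only part of what the source reports. "The series", "measured", "known", "first", "only" and "open" are said of these compounds alone.

Measured so far in a functional assay on L1210 cells (Mus musculus) for cytotoxicity; on this read-out higher numbers stand for weaker inhibition and lower numbers for stronger inhibition:
compound 1 `Cc1cccc(C)c1NC(=O)/C=C/C(=O)N1C/C(=C\c2ccc([N+](=O)[O-])cc2)C(=O)/C(=C/c2ccc([N+](=O)[O-])cc2)C1` — 690 nM
compound 2 `Cc1ccc(NC(=O)/C=C/C(=O)N2C/C(=C\c3ccccc3)C(=O)/C(=C/c3ccccc3)C2)cc1` — 5800 nM
compound 3 `CC(=O)c1ccc(NC(=O)/C=C/C(=O)N2C/C(=C\c3ccccc3)C(=O)/C(=C/c3ccccc3)C2)cc1` — 5500 nM

Compound 1 gives the lowest of the three numbers in this assay; compound 3 and compound 2 both stand higher, and each gap to compound 1 is beyond the scatter. Among the compounds with values here, compound 1 differs from compounds 2 and 3 in more than one place, so no single step between them is defined; their values only show that the dinitro compound is the more potent one here.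

Compound 4 `O=C(/C=C/C(=O)N1C/C(=C\c2ccc([N+](=O)[O-])cc2)C(=O)/C(=C/c2ccc([N+](=O)[O-])cc2)C1)Nc1ccc(Cl)c(Cl)c1` is not yet measured. It differs from compound 1 in one place: 3,4-dichlorophenyl in place of 2,6-dimethylphenyl on an amide-type nitrogen.

Within the data shown here, the only measured single step, a 1.1-fold lower number from compound 2 to compound 3 (0.02 log units; within the scatter), also changes the substituent on the aryl amide, though with a different pattern and on a different pair of compounds. It was within the scatter. Nothing measured addresses a dichloro pattern or the move of substituents to other ring positions, so the bearing of that step on compound 4 is weak. On this basis no step beyond the scatter is expected from compound 1 to compound 4: a 1.0-fold higher number from compound 1 to compound 4 (0.01 log units; within the scatter). Compound 4 is therefore estimated at 700 nM, expected between 250 nM and 2000 nM.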

Compound 4, half-maximal inhibitory concentration: 1700 nM
For compound 4 the middle estimate is 2.4-fold (0.39 log units) below the measured one; the measured number falls inside the stated range.
By their numbers in this assay, from the lowest: compound 1; then compound 4; then compounds 3 and 2 (each within the scatter of the next).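

In this assay, within the data shown here, the group on the amide-type nitrogen can shift the number on the core of compound 1: 3,4-dichlorophenyl in place of 2,6-dimethylphenyl gives a 2.5-fold higher number from compound 1 to compound 4 (0.39 log units; beyond the scatter), a modest step, whereas the only earlier aryl amide change, a 1.1-fold lower number from compound 2 to compound 3 (0.02 log units; within the scatter), stayed within the scatter. The exchange alters the substituents and their ring positions together, and this single pair cannot separate the two, while the heavy-atom, donor and acceptor counts and the net charge of the two groups do not tell them apart. No supporting measurement bears on why this step arises.

On these data alone, it remains open whether a single chlorine or a single methyl on this aryl ring would account for the step, and whether the same exchange on the core of compound 2 would give a step of similar size. Also open, as far as these compounds go, is how an amine or a carboxylic acid on the aryl ring, or a longer chain in place of the aryl group, would read out in this assay.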